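One More Methyl on the Sulfonamide Nitrogen

The source may hold more compounds than are shown below. What is called first, only, known or untested is meant among the compounds shown, and "the series" means these compounds.

Values so far in an ADME assay on microsomes from liver (Mus musculus) for metabolic stability, tested at 5 uM (a lower number here means that the compound disappears faster, a higher number that the compound lasts longer), for each compound
- compound 1 `CCCCCCNc1ccc([N+](=O)[O-])cc1S(=O)(=O)N(C)C` gives < 0.0834 h
- compound 2 `CCCCCCNc1ccc(C(=O)O)cc1S(N)(=O)=O` gives > 1 h
- compound 3 `CCCCCCNc1ccc(C(=O)O)cc1S(=O)(=O)NC` gives 0.483 h

The reading of compound 1 at < 0.0834 h is a limit of the assay and not a number. For compound 2 the reading > 1 h is also a limit and not a number. That leaves compound 3 at 0.483 h as the only true half-life of the three.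

Compound 4 `CCCCCCNc1ccc(C(=O)O)cc1S(=O)(=O)N(C)C` has not been measured yet. It differs from compound 3 by methyl in place of hydrogen on a sulfonamide nitrogen and this is methyl in place of hydrogen on a sulfonamide nitrogen, turning methylsulfamoyl to dimethylsulfamoyl.

Going by the values given here, the same swap has been measured once, and an at least 2.0-fold lower number from compound 2 to compound 3 (0.31 log units; beyond the scatter) is the one step that bears on this. Compound 1 also carries dimethylsulfamoyl, but it differs from compound 4 elsewhere on the core, so it offers no clean comparison. A single step is a thin base, yet a second fall in half-life is the likeliest outcome in this assay for this swap. The expected change is a 2.0-fold lower number from compound 3 to compound 4 (0.30 log units; within the scatter) as an estimate. Compound 4 is estimated at 0.24 h with an expected range from 0.09 h to 0.55 h for its half-life.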

Compound 4, half-life: 0.283 h
Compound 4: the middle estimate sits 1.2-fold (0.07 log units) below what was measured, and the stated range covers the measured number.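

In this assay, the second methyl on the sulfonamide nitrogen gives a 1.7-fold lower number from compound 3 to compound 4 (0.23 log units; within the scatter) and so, taken alone, cannot be told apart from the ordinary spread of repeat measurements, whereas the first methyl step was printed as beyond that spread. Taken together, the full change of dimethylamino in place of amino on the sulfonyl sulfur gives an at least 3.5-fold lower number from compound 2 to compound 4 (0.54 log units; beyond the scatter) and does clear the scatter, though this size is only a floor, since it starts from a limit of the assay and not from a number: the limit of > 1 h in this assay, at which 1 of the 4 values shown sits. With dimethylsulfamoyl held fixed, carboxy in place of nitro on an aromatic carbon gives an at least 3.3-fold higher number from compound 1 to compound 4 (0.53 log units; beyond the scatter) and is again only a floor, since compound 1 also stands at a limit: the limit of < 0.0834 h in this assay, at which 1 of the 4 values shown sits.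

Still open, on these data alone, is how this nitrogen would read with a larger group on it, such as an ethyl or a cyclopropyl, or with the nitrogen closed into a pyrrolidine ring. Also open, as far as these compounds go, is whether the same methyl steps would hold on a core with an amide in place of the carboxylic acid, or with a longer chain on the amine.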